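From hydroxymethyl to fluoromethyl on compound 3

A few compounds are considered here, and "the series" means these few. Any claim that something is new, unique, unknown or untested is made for them only; others in the source may bear on it.

In a functional assay on HeLa cells (Homo sapiens) for cytotoxicity, read by WST assay, with a stated time of 48 h (on this read-out lower numbers stand for stronger inhibition and higher numbers for weaker inhibition), compound 3 (`COc1cc(C(c2ccc(O)c(OC)c2)[C@H](C)[C@H](C)CO)ccc1O`) reads > 100000 nM, which is a limit and not a number. Compound 1 (`COc1cc(C(c2ccc(O)c(OC)c2)[C@@H](C)[C@@H](C)CO)ccc1O`) reads > 100000 nM, which is also a limit. Their relation is the fact that compounds 1 and 3 differ only in the configuration as drawn, and the record between them is a step that the two limits leave unreadable from compound 1 to compound 3. The series is dominated by the limit of > 100000 nM in this assay, at which 2 of the 3 values shown sit. In this assay, among the measured compounds shown here, compound 2 (`COC[C@H](C(C)C)C(c1ccc(O)c(OC)c1)c1ccc(O)c(OC)c1`), which carries 1-(methoxymethyl)-2-methylpropyl, gives 76000 nM as the only true number. From there the record reads an at least 1.3-fold higher number from compound 2 to compound 3 (0.11 log units; that floor lies within the scatter).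

Compound 4 (`COc1cc(C(c2ccc(O)c(OC)c2)[C@@H](C)[C@@H](C)CF)ccc1O`) is defined by this change: 2-(fluoromethyl)-1-methylpropyl in place of 2-(hydroxymethyl)-1-methylpropyl on a saturated chain carbon bound to two aromatic carbons. The site is still a saturated chain carbon bound to two aromatic carbons. For the measured compounds named here, the only guide is compound 2, which also lacks the hydroxymethyl group, and it is seen in an at least 1.3-fold lower number from compound 1 to compound 2 (0.11 log units; that floor lies within the scatter). A small lowering in this assay is therefore expected, possibly none beyond the scatter. The expected step is an at least 1.4-fold lower number from compound 3 to compound 4 (0.15 log units; that floor lies within the scatter) in this estimate. Compound 4 is estimated at 70000 nM as a middle value, with an expected range from 25000 nM to 150000 nM overall, and it may well return only a limit.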

Compound 4, half-maximal inhibitory concentration: 42000 nM
Compound 4: middle estimate off by 1.7-fold (0.22 log units), on the high side, and the stated range covers the measured number.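

In this assay, among the compounds shown here, the change to 2-(fluoromethyl)-1-methylpropyl from 2-(hydroxymethyl)-1-methylpropyl, on a saturated chain carbon bound to two aromatic carbons, is the first to read beyond the scatter: the record gives an at least 2.3-fold lower number from compound 1 to compound 4 (0.37 log units; beyond the scatter) and an at least 2.3-fold lower number from compound 3 to compound 4 (0.37 log units; beyond the scatter). Both steps are floors and not full sizes, because each starts from a compound that reads only as a limit: the limit of > 100000 nM in this assay, at which 2 of the 4 values shown sit. The step from the 1-(methoxymethyl)-2-methylpropyl chain to the fluoromethyl chain shows no separation: a 1.8-fold lower number from compound 2 to compound 4 (0.26 log units; within the scatter).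

For the compounds shown here, what configuration contributes at this position stays open, and the one step that bears on it cannot be read: the fact that compounds 1 and 3 differ only in the configuration as drawn. Also open, going by these compounds, is how an amine or a carboxylic acid on this chain would read against the fluoromethyl chain.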